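Series notes on the step from compound 2 to compound 3

This account rests on a few compounds, and the source may have more. Where it says the series, first, only, none or still open, it means among the compounds named here.

Of the compounds shown here, two carry numbers so far. Compound 1 `COc1ccc(-c2c(Br)c(=O)c3c(OC)cc(OC)cc3n2S(=O)(=O)c2ccc(OC)cc2)cc1` was run in a functional assay on KOPN-8 cells (Homo sapiens) for antiproliferative activity, with a stated time of 72 h (on this read-out higher numbers stand for an effect only at larger amounts of compound and lower numbers for an effect already at smaller amounts), and compound 1 gives 2580 nM. Compound 2 `COc1cc(OC)c2c(=O)cc(C(=O)Nc3ccc(C4CCCCC4)cc3)[nH]c2c1` gives 18400 nM in the same read-out, the higher of the two numbers; compound 1 sits lower, and that gap lies beyond the usual scatter. The two structures differ in many places at once, so nothing more is taken from that gap than what the two values show.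

Compound 3 `COc1cc(OC)c2c(=O)cc(C(=O)Nc3ccc(Oc4ccc(F)cc4)cc3)[nH]c2c1` differs from compound 2 in one place: 4-fluorophenoxy in place of cyclohexyl on an aromatic carbon. Among the compounds with values here, no step between two measured compounds isolates such a change, so the expectation rests on compound 2 alone. For compound 3 a modest shift toward a lower number is expected in a 1.8-fold lower number from compound 2 to compound 3 (0.26 log units; within the scatter), of a size that may not clear the scatter. The estimate for compound 3 is 10000 nM, with a range from 3000 nM to 40000 nM.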

Compound 3, half-maximal effective concentration: > 50000 nM
Compound 3: a limit, no number; the forecaster's own chance of this, stated with the estimate: 15%; middle value at least 5.0-fold (0.69 log units) away from the limit.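

Within the data shown here, the change to 4-fluorophenoxy in place of cyclohexyl on this aromatic carbon, para to a large group, gives an at least 2.7-fold higher number from compound 2 to compound 3 (0.43 log units; beyond the scatter) in this assay, the first step that isolates a single place. It shows that this position is not indifferent to the group it carries, and that swapping the non-aromatic ring for the larger aromatic group does not bring the number down. For compound 3 the result is a limit of the assay and not a number, so only the direction and a minimum size of the step are known: the limit of > 50000 nM in this assay, at which 1 of the 3 values shown sits.

The compounds shown do not separate the contributions of the oxygen, the fluorine and the aromatic ring within the entering group. On these data alone, how an amine, a carboxylic acid or a longer chain on this carbon would read also remains open.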